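Methoxy for Trifluoromethyl on a Urea Aromatic Ring

The source may report more compounds than this note shows. Statements on the series, on what has been measured and on what is new or still open speak of the compounds shown alone.

Compound 1 `CC(C)c1ccccc1NC(=O)N[C@H](C)c1ccccc1` and compound 2 `C[C@@H](NC(=O)Nc1ccccc1C(F)(F)F)c1ccccc1` share a urea core and differ only at one aromatic carbon. In an ADME assay on the whole organism with Oryza sativa as the target, tested at 1 uM (a higher number here means a weaker effect of the compound at the concentration tested, a lower number a stronger effect), compound 1 gives 101%, and in this assay compound 2 gives 95%, so compound 2 stands at the lower of the two numbers, yet the step of a number 6 percentage points lower from compound 1 to compound 2 (within the scatter) lies within the scatter, and the two values cannot be ordered. Compound 3 `COc1ccccc1NC(=O)N[C@H](C)c1ccccc1` has not yet been measured in this assay. The change from compound 2 is methoxy in place of trifluoromethyl on an aromatic carbon. For the measured compounds named here, the one measured step, that from compound 1 to compound 2, also exchanged a group at this aromatic carbon and stayed within the scatter; no step with a methoxy is at hand. For compound 3 a step of a number 2 percentage points higher from compound 2 to compound 3 (within the scatter) is therefore expected, nothing beyond the scatter. The estimate for compound 3 in this assay is 97%, between 84% and 108%.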

Compound 3, a percentage reported as activity, at one concentration (the size of the read-out at that concentration, not a potency): 105%
Compound 3: the middle estimate sits 8 percentage points below what was measured, and the stated range covers the measured number.
By their numbers in this assay, from the lowest: compounds 2, 1 and 3 (each within the scatter of the next).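

In this assay, methoxy in place of trifluoromethyl on this aromatic carbon, ortho to a large group, gives a number 10 percentage points higher from compound 2 to compound 3 (within the scatter), and methoxy in place of isopropyl gives a number 4 percentage points higher from compound 1 to compound 3 (within the scatter). Methoxy brings one hydrogen-bond acceptor where trifluoromethyl has none, yet the three groups now seen at this carbon cannot be told apart in this read-out, so none of these exchanges has shown that the choice among them matters. No measurement at hand bears on why this is so.

What the compounds shown leave open is whether any group at this carbon can move the number beyond the scatter, for example an amine, a carboxylic acid or a longer chain. They also leave open whether the other carbons of this aromatic ring would respond any differently.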